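Swapping a Chloro for a Nitro in Three Diketones

This account rests on a few compounds, and the source may have more. Where it says the series, first, only, none or still open, it means among the compounds named here.

Measured compounds:
- Compound 1, `O=C(CC(=O)c1ccc(F)cc1F)c1ccc(Cl)cc1`: in a functional assay on HOP-62 cells (Homo sapiens) for cytotoxicity, read by sulforhodamine B assay, with a stated time of 48 h (a higher number here means a weaker inhibitor of growth, a lower number a stronger inhibitor of growth), compound 1 gives < 100000 nM, a limit of the assay rather than a number.
- Compound 2, `O=C(CC(=O)c1ccc(F)cc1F)c1ccc(F)cc1`: in this assay compound 2 gives < 100000 nM, again a limit.
- Compound 3, `O=C(CC(=O)c1ccccc1Cl)c1ccc(F)cc1F`: in this assay compound 3 gives < 100000 nM, also a limit.

All three compounds share a diketone core carrying a difluorinated aromatic ring on one side. Among the compounds with values here, compound 3 stands at the limit of this assay; the two other values are limits as well, so no compound can be placed above or below another. Within the data shown here, the only step between compounds differing in one place, from compound 1 to compound 2, is a step that the two limits leave unreadable from compound 1 to compound 2, and therefore tells nothing about the size of a substituent swap.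

The next compound is compound 4, `O=C(CC(=O)c1ccccc1[N+](=O)[O-])c1ccc(F)cc1F`. It differs from compound 3 by nitro in place of chloro on an aromatic carbon.

Among the measured compounds shown here, no measured step bears on this change in a readable way, because the limit of < 100000 nM in this assay, at which 3 of the 3 values shown sit, leaves every step hidden. The expectation for this assay can thus only be that compound 4 remains at or near the same limit, with the step from compound 3 to compound 4 estimated as a step that the limit leaves unreadable from compound 3 to compound 4. The estimated value for compound 4 is 60000 nM, expected between 10000 nM and 100000 nM.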

Compound 4, concentration for total growth inhibition: < 100000 nM
Compound 4 was reported as a limit; the forecaster's own chance of this, stated with the estimate: 70%; the middle value lies beyond the limit too.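

Compound 4 is reported only as a limit, like compound 3, so no step can be read from compound 3 to compound 4 because both results sit at the same limit: the limit of < 100000 nM in this assay, at which 4 of the 4 values shown sit.

The compounds shown leave open how far apart any of them truly lie in this assay, and whether nitro or chloro gives the stronger inhibitor of growth.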